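Moving the methoxy groups: compound 2 to compound 3

A few compounds are considered here, and "the series" means these few. Any claim that something is new, unique, unknown or untested is made for them only; others in the source may bear on it.

Measured in a functional assay on HepG2 cells (Homo sapiens) for antiproliferative activity, read by sulforhodamine B assay, with a stated time of 48 h; a lower number here means a stronger inhibitor, a higher number a weaker inhibitor:
- compound 1 `COc1ccc(-c2ccccc2C(=O)/C=C/c2ccc(F)cc2)cc1OC`: 4300 nM
- compound 2 `COc1ccc(/C=C/C(=O)c2ccccc2-c2ccc(OC)c(OC)c2)cc1OC`: 3200 nM

Compound 2 stands at 3200 nM and compound 1 at 4300 nM. These two values lie within the scatter of each other, so neither ranks ahead. The next compound to be tested is compound 3 `COc1ccc(OC)c(/C=C/C(=O)c2ccccc2-c2ccc(OC)c(OC)c2)c1`, which has 2,5-dimethoxyphenyl in place of 3,4-dimethoxyphenyl on a double-bonded chain carbon bound to a double-bonded chain carbon.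

Among the compounds with values here, one measured step bears on this place, a 1.3-fold lower number from compound 1 to compound 2 (0.13 log units; within the scatter). Even that exchange of 4-fluorophenyl for 3,4-dimethoxyphenyl stayed within the scatter. Within the data shown here, no measured pair shows what rearranging the two methoxy groups does, so this evidence is indirect. In this assay, no step beyond the scatter is expected, and no direction can be favoured. The estimate for compound 3 is 3000 nM, with an expected range from 1200 nM to 7500 nM. The estimate thus amounts to an expected 1.1-fold lower number from compound 2 to compound 3 (0.03 log units; within the scatter).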

Compound 3, half-maximal inhibitory concentration: 2100 nM
The estimate for compound 3 lay 1.4-fold (0.15 log units) above the measured number; the measured number falls inside the stated range.
By their numbers in this assay, from the lowest: compounds 3, 2 and 1 (each within the scatter of the next, the first and the last beyond it).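

In this assay, moving the two methoxy groups yields a 1.5-fold lower number from compound 2 to compound 3 (0.18 log units; within the scatter), so at this place, on a double-bonded chain carbon bound to a double-bonded chain carbon, the 2,5-dimethoxyphenyl and 3,4-dimethoxyphenyl arrangements cannot be told apart. Within the data shown here, the comparison with 4-fluorophenyl does separate for the first time, with a 2.0-fold lower number from compound 1 to compound 3 (0.31 log units; beyond the scatter), although this step is modest and compound 2 did not separate from compound 1 in the same way, so the result rests on one pair and marks no trend across the three compounds. No measurement on hand offers an explanation for either step.

The compounds shown leave open whether the number at this place would hold with a phenyl group bearing an amine or a carboxylic acid, or with a single methoxy group, since only methoxy and fluoro substituents appear here. The other 3,4-dimethoxyphenyl on the shared core is common to compound 1, compound 2 and compound 3, so what a change there would do cannot be read from this set.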